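This account rests on a few compounds, and the source may have more. Where it says the series, first, only, none or still open, it means among the compounds named here.

Compound 1 `O=C(O)c1ccccc1-c1ccc(CCc2ncc(Cc3cccc(F)c3)[nH]2)cc1`: 159 nM in an in vitro functional assay on cells for agonist activity at Bombesin receptor subtype-3 (Homo sapiens), read by luminescence and calcium flux; a higher number here means that more compound is needed for the effect, a lower number that less compound is needed
Compound 2 `CCCCc1cnc(CCc2ccc(-c3ccccc3C(=O)O)cc2)[nH]1`: 2710 nM

Going by the values given here, compound 2 gives the highest of the two numbers in this assay; its nearest neighbour is compound 1, and the sole measured step, a 17-fold higher number from compound 1 to compound 2 (1.23 log units; beyond the scatter), is large. Compound 3 `CC(C)(C)CCc1cnc(CCc2ccc(-c3ccccc3C(=O)O)cc2)[nH]1` differs from compound 2 by tert-butyl in place of ethyl on a saturated chain carbon, two bonds along the chain from an aromatic carbon. No measured step tests this change; the one step shown concerns the exchange of a propyl for a 3-fluorophenyl and does not bear directly on it. A small step toward a lower number is therefore expected, a 1.5-fold lower number from compound 2 to compound 3 (0.18 log units; within the scatter), with wide uncertainty. Compound 3 is estimated at 1800 nM, between 500 nM and 6000 nM.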

Compound 3, half-maximal effective concentration: 39 nM
For compound 3 the middle estimate is 46-fold (1.66 log units) above the measured one; the measured number lies below the stated range.
By their numbers in this assay, from the lowest: compound 3; then compound 1; then compound 2.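

In this assay, the chain on the shared core responds far more strongly than the earlier pair could show: tert-butyl in place of ethyl, on a saturated chain carbon two bonds along the chain from an aromatic carbon, gives a 69-fold lower number from compound 2 to compound 3 (1.84 log units; beyond the scatter). An aromatic ring is also not required here, since neopentyl in place of 3-fluorophenyl gives a 4.1-fold lower number from compound 1 to compound 3 (0.61 log units; beyond the scatter). Nothing available explains either step.

From the compounds shown here alone, whether a cyclohexyl group or a longer branched chain would match tert-butyl at this place remains open, as does whether a hydroxyl or an amine on the chain would be tolerated.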